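Methyl in place of hydrogen on the pyrazole of compound 1

A few compounds are considered here, and "the series" means these few. Any claim that something is new, unique, unknown or untested is made for them only; others in the source may bear on it.

Compound 1 `CNC(=O)N1CCCc2ccc(NC(=O)c3cccc(-c4cc[nH]n4)c3)cc21` and compound 2 `CNC(=O)N1CCCc2ccc(NC(=O)c3ccc(-c4cnn(C(C)=O)c4)cc3)cc21` share a common core and differ in the aromatic group attached to the benzamide. In a functional assay on MV4-11 cells (Homo sapiens) for antiproliferative activity, with a stated time of 6 days, tested at 6.25 uM (on this read-out higher numbers stand for a stronger effect at the one concentration tested and lower numbers for a weaker effect), compound 1 gives 89.7%, and in this assay compound 2 gives 83.8%. Compound 1 holds the larger of the two numbers, but the gap to compound 2 lies within the usual scatter of repeated measurements, so the two cannot be told apart on this read-out. For the measured compounds named here, no pair of measured compounds differs in only one place, so no single step has been measured.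

Compound 3 `CNC(=O)N1CCCc2ccc(NC(=O)c3cccc(-c4ccn(C)n4)c3)cc21` differs from compound 1 by methyl in place of hydrogen on an aromatic nitrogen, the 1H-pyrazol-3-yl becoming a 1-methyl-1H-pyrazol-3-yl. Going by the values given here, no measured pair tests this change. Because compound 1 already gives 89.7%, close to the top of the scale, the change from compound 1 to compound 3 is expected to be small, a number 5.7 percentage points lower from compound 1 to compound 3 (within the scatter), and within the scatter, with any movement more likely downward than upward. Compound 3 is therefore estimated at 84% in this assay, with a range from 60% to 96%.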

Compound 3, a percentage reported as inhibition, at one concentration (the size of the read-out at that concentration, not a potency): 99.5%
Compound 3: the middle estimate sits 15.5 percentage points below what was measured, outside the stated range (above it).
By their numbers in this assay, from the lowest: compounds 2, 1 and 3 (each within the scatter of the next, the first and the last beyond it).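

In this assay the exchange of hydrogen for methyl on the aromatic nitrogen of the five-membered ring gives a number 9.8 percentage points higher from compound 1 to compound 3 (within the scatter) and is the first single change measured among these compounds. It shows that the hydrogen on this nitrogen is not needed for the effect at the one concentration tested: compound 3 carries no hydrogen there, yet it cannot be told apart from compound 1 on this read-out. The position therefore accepts at least one added carbon without a loss that can be read, although the step is too small to count as a gain for the 1-methyl-1H-pyrazol-3-yl over the 1H-pyrazol-3-yl.

The compounds shown leave open whether a longer chain on this nitrogen, such as ethyl or propyl, or a chain ending in an amine or a carboxylic acid, would give a read-out of similar size. They also leave open whether compound 1 and compound 3 would separate at lower concentrations, and nothing given here accounts for how closely the two compounds read.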